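The source may hold more compounds than are shown below. What is called first, only, known or untested is meant among the compounds shown, and "the series" means these compounds.

Of the compounds shown here, three built on one shared core have been measured in a functional assay on DLD-1 cells (Homo sapiens) for antiproliferative activity, read by CellTiter-Glo, with a stated time of 72 h; on this read-out lower numbers stand for stronger inhibition and higher numbers for weaker inhibition. Compound 1 `COc1ccccc1-c1ccc(S(=O)(=O)N2CCC(N3CCC(C)CC3)CC2)cc1` gives 26 nM, and compound 3 `CC1CCN(C2CCN(S(=O)(=O)c3cccc(Br)c3)CC2)CC1` gives 3.2 nM. Compound 2 `CCc1ccc(S(=O)(=O)N2CCC(N3CCC(C)CC3)CC2)cc1` returns only a limit of the assay, > 5000 nM, so its true figure is not known beyond that boundary (the limit of > 5000 nM in this assay, at which 1 of the 3 values shown sits). Both measured steps that touch compound 2 are large: an at least 190-fold higher number from compound 1 to compound 2 (2.28 log units; beyond the scatter), and an at least 1500-fold lower number from compound 2 to compound 3 (3.19 log units; beyond the scatter). Together they show that the group on the aryl ring of the sulfonyl unit sets the whole range seen here, with the ethyl-bearing ring at the weak end.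

Compound 4 `CC1CCN(C2CCN(S(=O)(=O)c3ccc(C(C)(C)C)cc3)CC2)CC1` differs from compound 2 by a single change: tert-butyl in place of ethyl on an aromatic carbon. The move from ethyl to tert-butyl is far smaller than the swap of an ethyl for a 2-methoxyphenyl that separated compound 2 from compound 1, and it keeps the same ring pattern that compound 3 abandoned. In this assay the expected step is an at least 1.6-fold lower number from compound 2 to compound 4 (0.22 log units; that floor lies within the scatter), modest against the large steps measured on either side. Compound 4 is therefore expected to remain weak, with an estimated 3000 nM and a plausible range from 500 nM to 20000 nM; a second limit reading would not be surprising.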

Compound 4, half-maximal inhibitory concentration: > 5000 nM
Compound 4 ended at the assay's limit (the forecaster's own chance of this, stated with the estimate: 45%); middle value at least 1.6-fold (0.22 log units) from the limit.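

Going from ethyl to tert-butyl, from 2 to 4 carbon heavy atoms, on an aromatic carbon para to a large group does not bring compound 4 off the limit in this assay, so a larger alkyl group at this place does not by itself restore a measurable potency. Replacing the 2-methoxyphenyl group with tert-butyl gives an at least 190-fold higher number from compound 1 to compound 4 (2.28 log units; beyond the scatter), which places a second, bulkier alkyl group at the weak end of the series, while the ring-bearing compound 1 stays far from it. The step between compound 2 and compound 4 cannot be read, and any difference between ethyl and tert-butyl stays hidden, as the series now has two compounds at one boundary: the limit of > 5000 nM in this assay, at which 2 of the 4 values shown sit.

From the compounds shown here alone, what remains open is whether activity at this place requires a ring, as in compound 1, or whether a non-alkyl group could also provide it; a plain phenyl, a cyclohexyl, an amine or a carboxylic acid there would help to separate these cases. Also open, going by these compounds, is how far below the limit either alkyl compound would fall with a wider concentration range.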